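Same Atoms, Now With a Drawn Double-Bond Configuration

A few compounds are considered here, and "the series" means these few. Any claim that something is new, unique, unknown or untested is made for them only; others in the source may bear on it.

Measured compounds:
Compound 1 `CC(=NNC(=S)Nc1ccccc1F)c1ccccn1` gives 3.1 nM
Compound 2 `CC(=NNC(=S)Nc1ccccc1)c1ccccn1` gives 6.8 nM
Compound 3 `CC(=NNC(=S)Nc1cccc([N+](=O)[O-])c1)c1ccccn1` gives 140 nM

All three were tested in a functional assay on T98G cells (Homo sapiens) for cytotoxicity, read by MTT assay, with a stated time of 48 h; a lower number here means a stronger inhibitor, a higher number a weaker inhibitor. Among them compound 1 stands with the lowest number. Its nearest neighbour is compound 2, reached through the step of a 2.2-fold higher number from compound 1 to compound 2 (0.34 log units; beyond the scatter), a modest change tied to the swap of fluoro for hydrogen on an aromatic carbon. The furthest is compound 3, and the step of a 21-fold higher number from compound 2 to compound 3 (1.31 log units; beyond the scatter) is large, tied to a nitro group entering on an aromatic carbon.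

Compound 4 `C/C(=N\NC(=S)Nc1ccccc1F)c1ccccn1` is the next compound to be considered. Compared with compound 1 the difference is the two compounds have the same atoms and bonds; at least one stereo element is drawn with a configuration in one of them and without one in the other: 1 of 1 stereo elements differ; a double bond is drawn without a configuration in compound 1 and E in compound 4. Nothing leaves and nothing enters; the two compounds share every atom and every bond.

Both measured steps concern a group leaving or entering an aromatic ring, so neither bears on a change that only fixes how the double bond is drawn. With identical atoms and bonds, no step beyond the usual scatter is expected in this assay, and the expected step is no change at the digits printed from compound 1 to compound 4 (within the scatter). The value for compound 4 is therefore estimated at 3.1 nM, within a range from 1.5 nM to 6.5 nM.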

Compound 4, half-maximal inhibitory concentration: 3.1 nM
Compound 4: the middle estimate sits on the measured number at the digits printed, within the range that was stated.
By their numbers in this assay, from the lowest: compounds 1 and 4 (each within the scatter of the next); then compound 2; then compound 3.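

Until this point, every step in this assay came from a group entering or leaving an aromatic carbon; here the atoms stay the same, and the reading is no change at the digits printed from compound 1 to compound 4 (within the scatter). For this fluoro compound, then, drawing the double bond as E rather than leaving it undefined comes with no measurable shift, so the two entries give the same picture of how the fluoro compound behaves in this test. The pair differs only in how the structure is recorded, not in its atoms or bonds, and that record alone is the contrast on offer: the fact that one of compounds 1 and 4 is drawn with a defined configuration and the other without, at the place where they differ.

The compounds shown leave open what a double bond drawn Z would give, and whether the material behind compound 1 held one form or a mixture of forms, since an undefined drawing does not settle that. Also open, as far as these compounds go, is whether the same agreement would hold for the parent phenyl compound or the nitro compound, and how a chloro, a methoxy or an amine on the aromatic ring would read against these values.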